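The compounds below may be only part of what the source reports. "The series", "measured", "known", "first", "only" and "open" are said of these compounds alone.

Working notes on the series. The three measured compounds share one core and differ only in the group on the six-membered aromatic ring of carbon only. Compound 1 `COc1cc2nc(N3CCN(S(=O)(=O)c4ccc(I)cc4)CC3)nc(N)c2cc1OC` gives 15000 nM in a functional assay on PC-3 cells (Homo sapiens) for inhibition; a higher number here means a weaker inhibitor, a lower number a stronger inhibitor. Compound 2 `COc1cc2nc(N3CCN(S(=O)(=O)c4ccc(S(C)(=O)=O)cc4)CC3)nc(N)c2cc1OC` gives 17000 nM in this assay, and the step of a 1.1-fold higher number from compound 1 to compound 2 (0.05 log units; within the scatter) lies within the scatter. Compound 3 `COc1cc2nc(N3CCN(S(=O)(=O)c4ccc(-c5ccccc5)cc4)CC3)nc(N)c2cc1OC` gives 4200 nM in this assay and stands lowest of the three numbers, with the steps of a 3.6-fold lower number from compound 1 to compound 3 (0.55 log units; beyond the scatter) and a 4.0-fold lower number from compound 2 to compound 3 (0.61 log units; beyond the scatter) both beyond the scatter and both modest.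

Compound 4 `CCCCc1ccc(-c2ccc(S(=O)(=O)N3CCN(c4nc(N)c5cc(OC)c(OC)cc5n4)CC3)cc2)cc1` differs from compound 3 by butyl in place of hydrogen on an aromatic carbon. Among the measured compounds shown here, no measured pair changes the phenyl itself; the three steps at hand all replace the whole group on that ring, and the two that bear most, a 3.6-fold lower number from compound 1 to compound 3 (0.55 log units; beyond the scatter) and a 4.0-fold lower number from compound 2 to compound 3 (0.61 log units; beyond the scatter), show the phenyl lowering the number modestly relative to iodo and methylsulfonyl. Whether a butyl on that phenyl, para to a large group, moves the number further is shown by no pair. The step of a 1.4-fold lower number from compound 3 to compound 4 (0.15 log units; within the scatter) is therefore expected to be small and likely within the scatter. Compound 4 is expected to give about 3000 nM in this assay, with a range from 1000 nM to 9000 nM.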

Compound 4, half-maximal inhibitory concentration: 3400 nM
Beside the measured number, compound 4's estimate is 1.1-fold (0.05 log units) below it; the range from low to high includes it.
By their numbers in this assay, from the lowest: compounds 4 and 3 (each within the scatter of the next); then compounds 1 and 2 (each within the scatter of the next).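

Among the compounds shown here, the added butyl, on an aromatic carbon para to a large group, leaves the number in this assay within the scatter, with a 1.2-fold lower number from compound 3 to compound 4 (0.09 log units; within the scatter), so this is the first sign that the outer phenyl can carry a chain of this size without a readable change. The larger 4-butylphenyl group also keeps the modest advantage seen with phenyl, with a 5.0-fold lower number from compound 2 to compound 4 (0.70 log units; beyond the scatter) and a 4.4-fold lower number from compound 1 to compound 4 (0.64 log units; beyond the scatter), both beyond the scatter; compound 4 therefore sits with compound 3, apart from compound 1 and compound 2. No measurement of any other property bears on this result.

Going by these compounds, whether any group at this place can move the number beyond the scatter of compound 3 remains open, whether a methyl, a longer chain such as octyl, an amine or a carboxylic acid. Also open, on these data alone, is whether the butyl would give the same result on another carbon of that ring, or whether a second ring attached there would do more than the chain.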